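A few compounds are considered here, and "the series" means these few. Any claim that something is new, unique, unknown or untested is made for them only; others in the source may bear on it.

In a physicochemical assay for solubility, measured as kinetic solubility, with a stated time of 1 h, at pH 7.4 (on this read-out higher numbers stand for higher solubility and lower numbers for lower solubility), compound 1 `O=C(NC1=NN(c2ccc(Cl)c(Cl)c2)CC1)c1ccncc1` gives 9000 nM and compound 2 `O=C(NC1=NN(c2ccc(Cl)c(Cl)c2)CC1CCO)c1cccnc1` gives 192000 nM as the higher of the two numbers, a gap beyond the scatter. Compound 3 `O=C(NC1=NN(c2ccc(Cl)c(Cl)c2)CC1CCO)c1ccncc1` follows from compound 2 by pyridin-4-yl in place of pyridin-3-yl on a carbonyl carbon. Going by the values given here, no measured pair shows this change alone, so the expectation is judgement rather than precedent. A small downward step in this assay is expected, with the estimated 1.6-fold lower number from compound 2 to compound 3 (0.20 log units; within the scatter) staying within the scatter. Compound 3 is estimated at 120000 nM (expected range 40000 nM to 250000 nM).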

Compound 3, solubility: 167000 nM
Compound 3: the middle estimate sits 1.4-fold (0.14 log units) below what was measured; measured number inside the range.
By their numbers in this assay, from the lowest: compound 1; then compounds 3 and 2 (each within the scatter of the next).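

In this assay, pyridin-4-yl in place of pyridin-3-yl on a carbonyl carbon gives a 1.1-fold lower number from compound 2 to compound 3 (0.06 log units; within the scatter), so this swap at this position does not separate the two compounds. Going by these compounds alone, with pyridin-4-yl held constant, 2-hydroxyethyl in place of hydrogen on a saturated ring carbon gives a 19-fold higher number from compound 1 to compound 3 (1.27 log units; beyond the scatter), the first reading of that change alone. From the compounds shown here alone, whether a longer chain, a carboxylic acid or an amine on that ring carbon would give a step of similar size stays open, as does pyridin-2-yl on the carbonyl carbon. No available measurement explains the size of either step.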